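Iodo in Place of Bromo on a Shared Core

This account rests on a few compounds, and the source may have more. Where it says the series, first, only, none or still open, it means among the compounds named here.

Of the compounds shown here, three have been tested in a toxicity assay on the whole organism (P388 cells) for cytotoxicity, with Mus musculus as the target, with a stated time of 9 days, at a dose of 40 mg/kg by the intraperitoneal route; on this read-out higher numbers stand for a weaker effect at the one dose given and lower numbers for a stronger effect. Compound 1 `CN(C)/N=N\c1ccnc2ccc(Br)cc12` gives -3.5%. Compound 2 `CN(C)/N=N\c1ccnc2cc(Cl)ccc12` gives -22.6% in this assay, and compound 3 `CN(C)/N=N\c1ccnc2c(Br)cccc12` gives -3.3%. Among these three numbers compound 1 stands second highest. Its nearest neighbour is compound 3, whose number lies within the usual scatter of that of compound 1, so the two cannot be told apart. The furthest is compound 2, whose number lies beyond the scatter and lower than that of compound 1, which on this read-out means a stronger effect at the one dose given. No two of these measured compounds differ in only one place, so no single-change step can be read off among them.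

Compound 4 `CN(C)/N=N\c1ccnc2ccc(I)cc12` has not yet been measured. It differs from compound 1 in one place: iodo in place of bromo on an aromatic carbon. One halogen is swapped for another on an aromatic carbon; one heavy atom leaves and one enters, with no change in rings, donors, acceptors or charge.

Among the measured compounds shown here, no measured pair shows what such a swap does here. The expectation rests on the small size of the change alone. The expected step is a number 1.5 percentage points lower from compound 1 to compound 4 (within the scatter), within the scatter and with no clear direction. Compound 4 is therefore estimated to give -5% in this assay, with a range from -25% to 15%.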

Compound 4, a percentage reported as activity, at one dose (the size of the read-out at that dose, not a potency): 10.5%
The estimate for compound 4 lay 15.5 percentage points below the measured number; low and high end bracket the measured number.
By their numbers in this assay, from the lowest: compound 2; then compounds 1 and 3 (each within the scatter of the next); then compound 4.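

In this assay, iodo in place of bromo on this aromatic carbon gives a number 14 percentage points higher from compound 1 to compound 4 (beyond the scatter), so the effect at the one dose given is weaker with iodo than with bromo. Among the compounds shown here, this is the only single-change step available on the shared core, and it shows that swapping one halogen for another at this place, with no change in rings, donors, acceptors or charge, can still move the number beyond the usual scatter. Nothing at hand explains the shift, and no measurement of any property of either group bears on it.

Still open, as far as these compounds go, is whether the same swap would give a similar step at other places on the core, as compound 2 and compound 3 carry their halogens elsewhere and neither has a partner that differs from it in only one place. Also open, from the compounds shown here alone, is what a group of a different kind, such as an amine or a methoxy group, would do on this same aromatic carbon, and where a chloro or fluoro there would fall relative to bromo and iodo.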